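Three limits, then a thiophene for a pyridine

The compounds below may be only part of what the source reports. "The series", "measured", "known", "first", "only" and "open" are said of these compounds alone.

Compound 1 `Cc1noc(C)c1C(c1ccccc1)N1CCN(c2ncnc3c2cnn3-c2ccccc2)CC1`: in a functional assay on cells (Rhabdomyosarcoma cell, Homo sapiens) for cytotoxicity (a higher number here means a weaker inhibitor, a lower number a stronger inhibitor), compound 1 gives > 25000 nM, a limit of the assay.
Compound 2 `Cc1ccsc1C(c1ccccn1)N1CCN(c2ncnc3c2cnn3-c2ccccc2)CC1`: in this assay compound 2 gives > 25000 nM, also a limit.
Compound 3 `c1ccc(C(c2ccccn2)N2CCN(c3ncnc4c3cnn4-c3ccccc3)CC2)cc1`: in this assay compound 3 gives > 25000 nM, again a limit.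

Compound 3 therefore stands where every value shown stands, at the limit of > 25000 nM in this assay, at which 3 of the 3 values shown sit. Compound 4 `Cc1ccsc1C(c1ccccc1)N1CCN(c2ncnc3c2cnn3-c2ccccc2)CC1` differs from compound 3 by 3-methylthiophen-2-yl in place of pyridin-2-yl on a saturated chain carbon bound to an amine nitrogen in a ring and an aromatic carbon. The two measured steps leading into compound 3, a step that the two limits leave unreadable from compound 1 to compound 3 and a step that the two limits leave unreadable from compound 2 to compound 3, give no readable size because both ends sit at the limit of > 25000 nM in this assay, at which 3 of the 3 values shown sit. The step that the limit leaves unreadable from compound 3 to compound 4 is thus expected to show no change beyond the scatter, with a limit again the likeliest report. Compound 4 is estimated at 30000 nM, within 15000 nM to 100000 nM.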

Compound 4, half-maximal inhibitory concentration: > 25000 nM
Compound 4: a limit, no number; the forecaster's own chance of this, stated with the estimate: 85%; the middle value lies beyond the limit too.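

Compound 4 gives > 25000 nM in this assay, a limit. Its steps to compound 1, compound 2 and compound 3 cannot be read, as all four compounds sit at one limit: the limit of > 25000 nM in this assay, at which 4 of the 4 values shown sit.

The compounds shown leave open whether any group on the saturated chain carbon would give a readable value.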